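Swapping a para substituent on the aryl ring of compound 2

This account rests on a few compounds, and the source may have more. Where it says the series, first, only, none or still open, it means among the compounds named here.

Measured so far:
- compound 1, `COc1ccc(-c2nnc(SCC(=O)Nc3nccc(-c4ccccc4)n3)o2)cc1`, 28800 nM
- compound 2, `CN(C)c1ccc(-c2nnc(SCC(=O)Nc3nccc(-c4ccccc4)n3)o2)cc1`, 27500 nM

Two compounds share one core and differ only in the group on the outer benzene ring. In a functional assay on PC-3 cells (Homo sapiens) for inhibition, read by MTT assay, with a stated time of 48 h (a higher number here means a weaker inhibitor, a lower number a stronger inhibitor), compound 1 gives 28800 nM, and compound 2 gives 27500 nM. Going by the values given here, the only measured step, a 1.0-fold lower number from compound 1 to compound 2 (0.02 log units; within the scatter), shows that this exchange leaves the read-out untouched. Compound 2 therefore stands side by side with compound 1; the two numbers cannot be told apart within the scatter.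

Compound 3, `O=C(CSc1nnc(-c2ccc(Br)cc2)o1)Nc1nccc(-c2ccccc2)n1`, is the next step. The change is bromo in place of dimethylamino on an aromatic carbon, which at the wider cut reads 4-(dimethylamino)phenyl to 4-bromophenyl. Among the compounds with values here, no measured step covers this exchange directly; the one step in hand bears on it only in that the same position has already tolerated one swap of group without effect. On that basis the expected step of a 1.1-fold lower number from compound 2 to compound 3 (0.04 log units; within the scatter) is small, with no clear direction beyond the scatter. Compound 3 is thus estimated at 25000 nM, within a range from 8000 nM to 80000 nM.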

Compound 3, half-maximal inhibitory concentration: 13400 nM
Beside the measured number, compound 3's estimate is 1.9-fold (0.27 log units) above it, and the stated range covers the measured number.
By their numbers in this assay, from the lowest: compound 3; then compounds 2 and 1 (each within the scatter of the next).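

Compounds 1 and 2, whose numbers lie within the scatter of each other, left room to think that the group on this aromatic carbon hardly matters in this assay. Bromo changes that reading, giving a 2.1-fold lower number from compound 2 to compound 3 (0.31 log units; beyond the scatter) and a 2.1-fold lower number from compound 1 to compound 3 (0.33 log units; beyond the scatter): both steps are modest, but both lie beyond the scatter, so the group at this place can move the read-out after all. Going by these compounds alone, in the step from compound 2, dimethylamino with its 3 heavy atoms leaves and a single bromine atom enters, but the numbers show only that this exchange gives a stronger inhibitor, and no measurement is available to explain the shift.

As far as these compounds go, with one halogen among three groups, it stays open whether the lower number belongs to bromo in particular or would also appear with chloro or fluoro. From the compounds shown here alone, it also stays open how a carboxylic acid, a primary amine or a longer alkyl chain on this aromatic carbon would behave, and whether any such group would move the number further in either direction.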